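A few compounds are considered here, and "the series" means these few. Any claim that something is new, unique, unknown or untested is made for them only; others in the source may bear on it.

Measured compounds in a functional assay on WiDr cells (Homo sapiens) for antiproliferative activity; a higher number here means a weaker inhibitor of growth, a lower number a stronger inhibitor of growth:
- compound 1 `CC(C)CC1OCCC(Cl)=C1[Si](C)(C)C`: 39000 nM
- compound 2 `C[C@H]1CC(Cl)=C([Si](C)(C)C)[C@@H](C2CCCCC2)O1`: 33000 nM
- compound 3 `CC[C@H]1CC(Cl)=C([Si](C)(C)C)[C@@H](C2CCCCC2)O1`: 73000 nM

Compound 3 gives the highest number of the three; the gap to compound 1 lies within the scatter, the gap to compound 2 is beyond it. Compound 4 `C[Si](C)(C)C1=C(Cl)C[C@H](Cc2ccccc2)O[C@@H]1C1CCCCC1` is not yet measured; it differs from compound 3 by phenyl in place of methyl on a saturated chain carbon bound to a saturated ring carbon. Among the compounds with values here, the only step at that place is a 2.2-fold higher number from compound 2 to compound 3 (0.34 log units; beyond the scatter), a modest rise upon enlarging the chain. A much larger group entering at the same place is expected, by extension, to move this assay in the same direction, at most modestly, though a single step is a thin basis. For compound 4 the expected step is a 1.4-fold higher number from compound 3 to compound 4 (0.14 log units; within the scatter). Compound 4 is therefore estimated at 100000 nM, with a range from 35000 nM to 280000 nM.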

Compound 4, concentration for total growth inhibition: 88000 nM
Estimate against measurement, compound 4: 1.1-fold (0.06 log units) above, and the stated range covers the measured number.
By their numbers in this assay, from the lowest: compounds 2, 1, 3 and 4 (each within the scatter of the next, the first and the last beyond it).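

In this assay, phenyl in place of methyl on a saturated chain carbon bound to a saturated ring carbon gives a 1.2-fold higher number from compound 3 to compound 4 (0.08 log units; within the scatter), so the much larger group with its aromatic ring is not told apart from methyl at this place. Phenyl in place of hydrogen at the same place gives a 2.7-fold higher number from compound 2 to compound 4 (0.43 log units; beyond the scatter), a modest step that lies beyond the scatter. Nothing at hand bears on what lies behind these steps.

Open, on these data alone, is whether an amine or a carboxylic acid at this place would move the number further. Also open, as far as these compounds go, is whether a longer chain without a ring would read like benzyl.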